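The source may hold more compounds than are shown below. What is called first, only, known or untested is meant among the compounds shown, and "the series" means these compounds.

Compound 1 `CCN(CC)c1ccc(/C=C/C(=O)c2ccc(OC)c3c2OC(C)(C)C=C3)cc1`, compound 2 `COc1ccc(C(=O)/C=C/c2ccc(N3CCCC3)cc2)c2c1C=CC(C)(C)O2` and compound 3 `COc1ccc(C(=O)/C=C/c2ccc([N+](=O)[O-])cc2)c2c1C=CC(C)(C)O2` share one core and differ only in a single group on an aromatic carbon. In a functional assay on HT-29 cells (Homo sapiens) for antiproliferative activity, read by MTT assay, with a stated time of 24 h (on this read-out lower numbers stand for stronger inhibition and higher numbers for weaker inhibition), compound 1 gives 550 nM, compound 2 gives 8360 nM and compound 3 gives 3730 nM. Compound 3 therefore holds the second highest of the three numbers, shown by a 2.2-fold lower number from compound 2 to compound 3 (0.35 log units; beyond the scatter) and by a 6.8-fold higher number from compound 1 to compound 3 (0.83 log units; beyond the scatter). Compound 4 `COc1ccccc1/C=C/C(=O)c1ccc(OC)c2c1OC(C)(C)C=C2` remains unmeasured and differs from compound 3 by 2-methoxyphenyl in place of 4-nitrophenyl on a double-bonded chain carbon bound to a double-bonded chain carbon. Going by the values given here, no measured step makes this same exchange; the nearest, a 6.8-fold higher number from compound 1 to compound 3 (0.83 log units; beyond the scatter) and a 2.2-fold lower number from compound 2 to compound 3 (0.35 log units; beyond the scatter), were modest, so a modest step in this assay, most likely toward a lower number, is expected. Compound 4 is estimated at 2500 nM, within 800 nM to 8000 nM. That corresponds to an expected 1.5-fold lower number from compound 3 to compound 4 (0.17 log units; within the scatter).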

Compound 4, half-maximal inhibitory concentration: > 10000 nM
Compound 4: no number, only a limit (the forecaster's own chance of this, stated with the estimate: 5%); at least 4.0-fold (0.60 log units) between middle value and limit.
By their numbers in this assay, from the lowest: compound 1; then compound 3; then compound 2. At a limit, above all of these: compound 4.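

In this assay, 2-methoxyphenyl in place of 4-nitrophenyl on a double-bonded chain carbon gives an at least 2.6-fold higher number from compound 3 to compound 4 (0.42 log units; beyond the scatter). The three earlier compounds all gave numbers, so this is the first change shown that carries a compound out of the measurable range. Compound 4 therefore has a limit, not a number, and the true size of the step stays unknown: the limit of > 10000 nM in this assay, at which 1 of the 4 values shown sits.

On these data alone, what remains open is whether the weaker result follows from the methoxy group itself or from its place on the ring. A 4-methoxyphenyl or 2-nitrophenyl group here could separate these two readings.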